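Replacing Fluoro with tert-Butyl on the Amide Aryl Ring

A few compounds are considered here, and "the series" means these few. Any claim that something is new, unique, unknown or untested is made for them only; others in the source may bear on it.

Of the compounds shown here, two built on a shared core have been measured in a functional assay on Ramos cells (Homo sapiens) for antiproliferative activity, read by CCK-8 assay, with a stated time of 72 h, tested at 40 uM; a higher number here means more inhibition at the concentration tested (going by the name of the read-out), a lower number less inhibition. Compound 1, `CCOC(=O)c1sc(-c2cccc(NC(=O)c3ccc(C(F)(F)F)cc3)c2)nc1Nc1ccc(N2CCN(C)CC2)cc1`, gives 18.4% in this assay. For the measured compounds named here, compound 2, `CCOC(=O)c1sc(-c2cccc(NC(=O)c3ccc(F)cc3)c2)nc1Nc1ccc(N2CCN(C)CC2)cc1`, gives 3.53%, which is the lowest of the two numbers; the only other compound, compound 1, lies higher by a margin beyond the scatter, as the step of a number 14.9 percentage points lower from compound 1 to compound 2 (beyond the scatter) shows, where fluoro replaced trifluoromethyl on an aromatic carbon.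

Compound 3, `CCOC(=O)c1sc(-c2cccc(NC(=O)c3ccc(C(C)(C)C)cc3)c2)nc1Nc1ccc(N2CCN(C)CC2)cc1`, has not yet been measured. It differs from compound 2 as follows: tert-butyl in place of fluoro on an aromatic carbon. Going by the values given here, the single step recorded, from trifluoromethyl to fluoro, is the only one that bears on this change, and it was modest in size. Since tert-butyl, like trifluoromethyl, is a group of several heavy atoms entering at the same aromatic carbon in place of fluoro, a modest rise is expected, roughly undoing that earlier loss.

For compound 3 in this assay the expected step is a number 12.5 percentage points higher from compound 2 to compound 3 (beyond the scatter). Compound 3 is therefore estimated at 16%, within a range from 0% to 34%.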

Compound 3, a percentage reported as inhibition, at one concentration (the size of the read-out at that concentration, not a potency): 21.2%
The estimate for compound 3 lay 5.2 percentage points below the measured number, within the range that was stated.
By their numbers in this assay, from the lowest: compound 2; then compounds 1 and 3 (each within the scatter of the next).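

In this assay the para position on the amide aryl ring now has a second group that separates from fluoro, with a number 17.7 percentage points higher from compound 2 to compound 3 (beyond the scatter) for tert-butyl entering in place of fluoro. The comparison of the two larger groups adds something the first step could not show: a number 2.8 percentage points higher from compound 1 to compound 3 (within the scatter) for tert-butyl in place of trifluoromethyl, so compound 1 and compound 3 cannot be told apart here, and compound 2 alone stands apart from the other two. No measurement is available that would explain this shared difference from fluoro.

Among the compounds shown, the substituents at this carbon are limited to fluoro, trifluoromethyl and tert-butyl, so it remains open whether a methoxy group, an amine, a carboxylic acid or a longer alkyl chain would read like compound 2 or like compound 3. As far as these compounds go, each reading also comes from a single concentration, so how the compounds would compare at other concentrations, and whether the same order would hold on other cell lines, also stays open.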